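The compounds below may be only part of what the source reports. "The series", "measured", "known", "first", "only" and "open" are said of these compounds alone.

Compound 1 `COC(=O)c1cccc(CC[C@H](SC[C@@H](C)C(=O)O)c2cccc(/C=C/c3ccc4ccc(Cl)cc4n3)c2)c1` gives 7 nM in an assay on membranes from lung for inhibition of cysteinyl leukotriene receptor 1 (Cavia porcellus) (on this read-out lower numbers stand for stronger inhibition and higher numbers for weaker inhibition), and compound 2 `CC(=O)c1ccccc1CC[C@H](SC[C@@H](C)C(=O)O)c1cccc(/C=C/c2ccc3ccc(Cl)cc3n2)c1` gives 3 nM. That step is a 2.3-fold lower number from compound 1 to compound 2 (0.37 log units; beyond the scatter), so compound 2 stands with the lower of the two numbers. Compound 3 `C[C@H](CS[C@@H](CCc1ccccc1C(=O)c1ccccc1)c1cccc(/C=C/c2ccc3ccc(Cl)cc3n2)c1)C(=O)O` differs from compound 2 by phenyl in place of methyl on a carbonyl carbon. Among the measured compounds shown here, only one measured step exists, a 2.3-fold lower number from compound 1 to compound 2 (0.37 log units; beyond the scatter), and it swapped whole aryl groups rather than touching a carbonyl carbon, so it bears on this change only loosely. Accordingly the expected step in this assay is no change at the digits printed from compound 2 to compound 3 (within the scatter), nothing beyond the scatter. Compound 3 is therefore estimated at 3 nM, within a range from 1.2 nM to 8 nM.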

Compound 3, half-maximal inhibitory concentration: 4.3 nM
Compound 3: the middle estimate sits 1.4-fold (0.16 log units) below what was measured; measured number inside the range.
By their numbers in this assay, from the lowest: compounds 2, 3 and 1 (each within the scatter of the next, the first and the last beyond it).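

Replacing acetyl with benzoyl puts a whole six-membered aromatic ring on the carbonyl carbon, yet in this assay the result is a 1.4-fold higher number from compound 2 to compound 3 (0.16 log units; within the scatter) and no more. This carbonyl carbon can therefore carry either methyl or phenyl without a change that stands out from the scatter, which the earlier swap of whole aryl groups could not show. Nothing measured here explains this. Still open, as far as these compounds go, is how an amine or an ethyl group on this carbonyl carbon would read out, and whether a longer chain there would also leave the number in place.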